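Removing the ring methyl from a selenophene-bearing quinolone

The source may report more compounds than this note shows. Statements on the series, on what has been measured and on what is new or still open speak of the compounds shown alone.

Measured compounds:
Compound 1, `COc1ccc2[nH]c(-c3ccc(C)[se]3)cc(=O)c2c1OC`: > 50000 nM
Compound 2, `COc1ccc2[nH]c(-c3ccc(C)[se]3)cc(=O)c2c1O`: 900 nM

In a functional assay on NCI-H460 cells (Homo sapiens) for cytotoxicity, read by MTT assay, with a stated time of 48 h (on this read-out lower numbers stand for stronger inhibition and higher numbers for weaker inhibition), compound 1 reaches only a limit of the assay, > 50000 nM. Going by the values given here, compound 2, `COc1ccc2[nH]c(-c3ccc(C)[se]3)cc(=O)c2c1O`, gives the one actual number in this assay, 900 nM, and so stands as the only measured compound with a number here. Among the compounds with values here, the single measured step, an at least 55-fold lower number from compound 1 to compound 2 (1.74 log units; beyond the scatter), rests on the limit of > 50000 nM in this assay, at which 1 of the 2 values shown sits, and concerns an oxygen substituent, not the selenophene.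

Compound 3, `COc1ccc2[nH]c(-c3cc[se]c3)cc(=O)c2c1O`, differs from compound 2 in a different place: a group of 5 heavy atoms (4 carbon, 1 selenium; one five-membered aromatic ring with 1 hetero atom) in place of a group of 6 heavy atoms (5 carbon, 1 selenium; one five-membered aromatic ring with 1 hetero atom), on an aromatic carbon. Within the data shown here, no measured step touches this change, so the expectation rests only on compound 2 and its value 900 nM. Compound 3 is therefore estimated to sit near compound 2, with a step of a 1.7-fold higher number from compound 2 to compound 3 (0.22 log units; within the scatter) that may not exceed the scatter. The estimate for compound 3 in this assay is 1500 nM, within 500 nM to 5000 nM.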

Compound 3, half-maximal inhibitory concentration: 800 nM
Compound 3: the middle estimate sits 1.9-fold (0.27 log units) above what was measured, within the range that was stated.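

In this assay, the step is a 1.1-fold lower number from compound 2 to compound 3 (0.05 log units; within the scatter), so compound 2 and compound 3 cannot be told apart on this read-out. Going by these compounds alone, this is the first measured change on the aromatic carbon next to the ring nitrogen, and it shows that a group of 5 heavy atoms (4 carbon, 1 selenium) can stand in place of a group of 6 heavy atoms (5 carbon, 1 selenium) there with no change beyond the scatter, whereas the earlier step concerned only the oxygen substituent. Nothing measured here bears on why these two groups give such similar numbers.

The compounds shown leave open how this position would respond to a group of another kind, such as an amine or a carboxylic acid. They also leave open whether a phenyl ring there would keep the number in the same range.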